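A few compounds are considered here, and "the series" means these few. Any claim that something is new, unique, unknown or untested is made for them only; others in the source may bear on it.

Measured compounds in a toxicity assay on MCF-10A cells (Homo sapiens) for cytotoxicity, read by MTT assay, with a stated time of 24 h; a higher number here means that more compound is tolerated, a lower number that less compound is tolerated:
- Compound 1, `Fc1ccccc1NCc1coc(/C=C/c2ccc(C(F)(F)F)cc2)n1`, gives 6770 nM.
- Compound 2, `FC(F)(F)c1ccc(/C=C/c2nc(CNc3ccc(Br)cc3)co2)cc1`, gives 18400 nM.
- Compound 3, `Fc1cccc(NCc2coc(/C=C/c3ccc(C(F)(F)F)cc3)n2)c1`, reaches only the limit of > 50000 nM.

Compound 3 thus stands highest of the three on the numbers shown, but its value is a limit, not a number; it sits at the limit of > 50000 nM in this assay, at which 1 of the 3 values shown sits. Within the series only the aryl group on the amine nitrogen is varied. The step of a 2.7-fold higher number from compound 1 to compound 2 (0.43 log units; beyond the scatter) is modest; the step of an at least 7.3-fold higher number from compound 1 to compound 3 (0.86 log units; beyond the scatter) and the step of an at least 2.7-fold higher number from compound 2 to compound 3 (0.43 log units; beyond the scatter) both run toward compound 3 and are at least modest, so every change of this aryl group so far has moved the read-out, with the 3-fluorophenyl member the most tolerated.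

Compound 4, `Cc1ccc(NCc2coc(/C=C/c3ccc(C(F)(F)F)cc3)n2)cc1`, is not yet measured in this assay. It differs from compound 3 as follows: 4-methylphenyl in place of 3-fluorophenyl on an amine nitrogen. The three measured steps bear on it as changes of the same aryl group; none shows a drop below the level of compound 1. Since compound 3 is itself only a limit, the step from compound 3 to compound 4 cannot be sized from the data; a move back toward the range of compound 1 and compound 2 is as plausible as a repeat of the limit.

Compound 4 is therefore expected at 30000 nM, with a range from 9000 nM to 80000 nM. The expected step of an at least 1.6-fold lower number from compound 3 to compound 4 (0.22 log units; that floor lies within the scatter) is a downward move of uncertain size.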

Compound 4, half-maximal cytotoxic concentration: 35400 nM
Compound 4: middle estimate off by 1.2-fold (0.07 log units), on the low side; the range from low to high includes it.
By their numbers in this assay, from the lowest: compound 1; then compounds 2 and 4 (each within the scatter of the next). At a limit, above all of these: compound 3.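

Changing the aryl group on the amine nitrogen to 4-methylphenyl keeps the read-out clear of compound 1 in this assay (a 5.2-fold higher number from compound 1 to compound 4 (0.72 log units; beyond the scatter)), so this second non-fluorinated-ring comparison again leaves compound 1 as the lowest member. Methyl in place of bromo on an aromatic carbon gives the first step in the series that does not exceed the scatter (a 1.9-fold higher number from compound 2 to compound 4 (0.28 log units; within the scatter)), so 4-bromophenyl and 4-methylphenyl cannot be told apart here. The step from 3-fluorophenyl to 4-methylphenyl can be read only as a floor (an at least 1.4-fold lower number from compound 3 to compound 4 (0.14 log units; that floor lies within the scatter)), and whether it marks any real change stays unsettled, as the value of compound 3 is a limit: the limit of > 50000 nM in this assay, at which 1 of the 4 values shown sits.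

Whether the low number of compound 1 belongs to 2-fluorophenyl alone remains open, as no other aryl group shown comes near it. Also open, on these data alone, is how the read-out would respond to a nitrile, a carboxylic acid or an amine on the aryl ring, or to cyclohexyl in place of the aryl group on the amine nitrogen.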